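The source may report more compounds than this note shows. Statements on the series, on what has been measured and on what is new or still open speak of the compounds shown alone.

Among the compounds with values here, compound 2, with structure `O=S(=O)(NCCCN1CCN(c2ccc(F)cc2)CC1)c1ccc2ccccc2c1`, stands at the lower end of the two numbers so far: in an assay on CHO cells for displacement of a labelled ligand from 5-hydroxytryptamine receptor 7 (Homo sapiens) (a higher number here means a weaker inhibitor, a lower number a stronger inhibitor), compound 2 gives 53 nM, whereas compound 1, with structure `COc1ccc(N2CCN(CCCNS(=O)(=O)c3ccc4ccccc4c3)CC2)cc1`, gives 3240 nM in this assay. Within the data shown here, the single measured step, a 61-fold lower number from compound 1 to compound 2 (1.79 log units; beyond the scatter), is the only comparison available for judging the next change.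

Compound 3, with structure `O=S(=O)(NCCCN1CCN(c2ccccc2)CC1)c1ccc2ccccc2c1`, differs from compound 2 by hydrogen in place of fluoro on an aromatic carbon. The same difference, cut one bond further out, reads 4-fluorophenyl to phenyl. Among the measured compounds shown here, no measured step removes a substituent from this ring altogether; the one step that touches this position exchanges methoxy for fluoro, and it was large. Because that step, a 61-fold lower number from compound 1 to compound 2 (1.79 log units; beyond the scatter), showed the group at this position mattering strongly, a change here is expected to move the number beyond the scatter, and hydrogen is expected to sit between the two measured outcomes, closer to fluoro than to methoxy.

Compound 3 is therefore expected to give 150 nM in this assay, within a range from 40 nM to 600 nM. The expected step of a 2.8-fold higher number from compound 2 to compound 3 (0.45 log units; beyond the scatter) is estimated to be toward a weaker inhibitor.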

Compound 3, half-maximal inhibitory concentration: 681 nM
Compound 3: middle estimate off by 4.5-fold (0.66 log units), on the low side; the whole stated range lies below it.
By their numbers in this assay, from the lowest: compound 2; then compound 3; then compound 1.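

The hydrogen compound separates what the earlier comparison could not: the gain seen on leaving methoxy was not simply the loss of that group, since in this assay there is a 13-fold higher number from compound 2 to compound 3 (1.11 log units; beyond the scatter) on taking fluoro away, a large step that shows fluoro itself is tied to the low number in this series. Removing methoxy alone accounts for only part of the earlier gain, with a 4.8-fold lower number from compound 1 to compound 3 (0.68 log units; beyond the scatter) in this assay, a modest step, so on this aromatic carbon both groups move the number away from that of the unsubstituted phenyl, and they move it in opposite directions. Among these three compounds, then, the position does not simply favour a smaller group, as methoxy lies on one side of hydrogen and fluoro on the other, and nothing at hand accounts for this difference between the two groups.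

Going by these compounds, whether chloro, methyl or an amine in place of fluoro on this aromatic carbon would also give a number lower than that of the phenyl compound remains open. Also open, on these data alone, is whether the difference between fluoro and hydrogen would stay as large with a longer chain in the shared core.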